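The source may hold more compounds than are shown below. What is called first, only, known or untested is meant among the compounds shown, and "the series" means these compounds.

Of the compounds shown here, three of this set have been tested in a functional assay on MCF7 cells (Homo sapiens) for antiproliferative activity, read by MTT assay, with a stated time of 72 h; on this read-out higher numbers stand for weaker inhibition and lower numbers for stronger inhibition. Compound 1 `CCNc1cc(C)c2cc(NC(=O)c3ccc(Cl)c(Cl)c3)ccc2n1` gives 48600 nM, compound 2 `CCN1CCN(c2cc(C)c3cc(NC(=O)c4ccc(Br)cc4)ccc3n2)CC1` gives 5940 nM, and compound 3 `Cc1cc(N2CCN(C(C)C)CC2)nc2ccc(NC(=O)c3ccc(Cl)c(Cl)c3)cc12` gives 1710 nM. Compound 2 thus holds the second highest of the three numbers: its value sits closer to that of compound 3, which is the lower of the two, than to that of compound 1, which is the highest of the set.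

Among the measured compounds shown here, the only step measured within a single change is a 28-fold lower number from compound 1 to compound 3 (1.45 log units; beyond the scatter), a large movement that concerns the group on the aromatic carbon of the core, not the amide side.

Compound 4 `CCN1CCN(c2cc(C)c3cc(NC(=O)c4ccc5ccccc5n4)ccc3n2)CC1` is the next compound to be measured. It differs from compound 2 in one place: quinolin-2-yl in place of 4-bromophenyl on a carbonyl carbon. For the measured compounds named here, this change sits on the carbonyl carbon, far from the place altered between compound 1 and compound 3, so no measured step bears on it directly, and the shared core together with the 4-ethylpiperazin-1-yl group is kept.

With nothing to guide the direction, compound 4 is expected to land near compound 2, and the step of a 1.5-fold lower number from compound 2 to compound 4 (0.17 log units; within the scatter) is estimated to be modest. Compound 4 is therefore expected to give about 4000 nM in this assay, within a range from 800 nM to 20000 nM.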

Compound 4, half-maximal inhibitory concentration: 7060 nM
Estimate against measurement, compound 4: 1.8-fold (0.25 log units) below; the measured number falls inside the stated range.
By their numbers in this assay, from the lowest: compound 3; then compounds 2 and 4 (each within the scatter of the next); then compound 1.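

In this assay, the change on the carbonyl carbon, the first measured on the amide side of the series, gives a step within the scatter (a 1.2-fold higher number from compound 2 to compound 4 (0.08 log units; within the scatter)). With the shared core and the 4-ethylpiperazin-1-yl group kept, this assay therefore does not separate 4-bromophenyl, a single ring of carbon only, from quinolin-2-yl, a larger group with a second aromatic ring that holds a hetero atom and a hydrogen-bond acceptor. Nothing measured here offers an explanation for this result, so it stands as an observation only.

On these data alone, the two groups compared at this position are both aromatic, so it remains open whether a saturated ring such as cyclohexyl, a short alkyl chain, or a phenyl ring carrying a carboxylic acid or an amine would also leave the number within the scatter. As far as these compounds go, it is equally open whether quinolin-2-yl and 4-bromophenyl would match each other with the ethylamino group of compound 1 or the 4-isopropylpiperazin-1-yl group of compound 3 on the aromatic carbon in place of 4-ethylpiperazin-1-yl.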